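Methoxy on the anilino ring: working notes toward compound 3

The source may hold more compounds than are shown below. What is called first, only, known or untested is meant among the compounds shown, and "the series" means these compounds.

Measured so far:
compound 1: `Cc1nc(SCC(=O)Nc2nc(-c3ccc(Cl)cc3)cs2)n(Nc2ccccc2)c1C`, 25800 nM
compound 2: `Cc1ccc(Nn2c(SCC(=O)Nc3nc(-c4ccccc4)cs3)nc(C)c2C)cc1`, 23800 nM
not yet measured:
compound 3: `COc1ccc(Nn2c(SCC(=O)Nc3nc(-c4ccc(Cl)cc4)cs3)nc(C)c2C)cc1`

In a functional assay on SK-MEL-5 cells (Homo sapiens) for antiproliferative activity, read by sulforhodamine B assay, with a stated time of 48 h (a higher number here means that more compound is tolerated, a lower number that less compound is tolerated), compound 1 gives 25800 nM and compound 2 gives 23800 nM. Compound 1 stands at the top of these two numbers, but the gap to compound 2 lies within the scatter, so the two are read as alike. Compound 3 differs from compound 1 by methoxy in place of hydrogen on an aromatic carbon. Among the measured compounds shown here, no measured pair shows this change, so nothing is known of its effect; from compound 1 and compound 2 alone, the step from compound 1 to compound 3 is expected to be a 1.1-fold lower number from compound 1 to compound 3 (0.03 log units; within the scatter), no larger than the scatter. Compound 3 is therefore estimated at 24000 nM, within 10000 nM to 60000 nM.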

Compound 3, concentration lethal to 50% of the cells: 7960 nM
Compound 3: the middle estimate sits 3.0-fold (0.48 log units) above what was measured; the measured number lies below the stated range.
By their numbers in this assay, from the lowest: compound 3; then compounds 2 and 1 (each within the scatter of the next).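

In this assay the anilino ring of compound 1 responds to substitution: phenyl to 4-methoxyphenyl gives a 3.2-fold lower number from compound 1 to compound 3 (0.51 log units; beyond the scatter) as a step beyond the scatter. Compound 1 and compound 2 differ in more than one place, so they could not isolate any single change on this ring. No measurement shown bears on the reason for this step.

On these data alone, whether another group at this place, such as an amine, a carboxylic acid or a longer alkoxy chain, would move the number the same way remains open. A single step also cannot show whether methoxy acts alike on other members of the series.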